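Inversion at the thiol-bearing carbon in a mercaptoacyl series

A few compounds are considered here, and "the series" means these few. Any claim that something is new, unique, unknown or untested is made for them only; others in the source may bear on it.

Three mercaptoacyl amino acid derivatives have been measured. In an assay on isolated protein for inhibition of Neprilysin (Oryctolagus cuniculus) (on this read-out higher numbers stand for weaker inhibition and lower numbers for stronger inhibition), compound 1 `Cc1ccc(CSC[C@@H](NC(=O)[C@@H](CS)Cc2ccc(-c3ccccc3)cc2)C(=O)O)cc1` gives 180 nM, compound 2 `O=C(N[C@H](CSCc1ccccc1)C(=O)O)[C@H](CS)Cc1ccccc1` gives 32 nM, and compound 3 `CSCC[C@@H](NC(=O)[C@@H](CS)Cc1ccccc1)C(N)=O` gives 76 nM. On these numbers compound 3 stands second highest of the three, separated from compound 1 and from compound 2 by steps beyond the scatter. Compound 4 `CSCC[C@@H](NC(=O)[C@H](CS)Cc1ccccc1)C(N)=O` differs from compound 3 only in configuration: the two compounds have the same atoms and bonds and differ only in configuration as drawn: 1 of 2 stereo elements differ; a stereocentre at a saturated chain carbon is drawn S in compound 3 and R in compound 4. Within the data shown here, no pair of measured compounds differs in a single place, so the series gives no measured guide to the effect of this inversion in this assay. A step of modest size in either direction cannot be ruled out. Compound 4 is expected to give 150 nM, with a range from 30 nM to 700 nM. This expectation amounts to a 2.0-fold higher number from compound 3 to compound 4 (0.30 log units; within the scatter), a step not expected to clearly exceed the scatter.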

Compound 4, half-maximal inhibitory concentration: 94 nM
The estimate for compound 4 lay 1.6-fold (0.20 log units) above the measured number; measured number inside the range.
By their numbers in this assay, from the lowest: compound 2; then compounds 3, 4 and 1 (each within the scatter of the next, the first and the last beyond it).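

In this assay, among these compounds, the step of a 1.2-fold higher number from compound 3 to compound 4 (0.09 log units; within the scatter) is the first that crosses a single change. It can be read as the inversion alone because of one fact: the fact that compounds 3 and 4 differ only in the configuration as drawn. Among the compounds shown here, in this pair, with its primary amide, S and R as drawn at this saturated chain carbon lie within the scatter of each other, which the earlier compounds could not show. Open, going by these compounds, is whether the inversion stays this small in compounds carrying a carboxylic acid, as compound 2 does. Also open, on these data alone, is how a hydroxamic acid in place of the thiol would read out.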